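Cytotoxicity on rat myoblasts: a methylpyridyl series

The compounds below may be only part of what the source reports. "The series", "measured", "known", "first", "only" and "open" are said of these compounds alone.

Measured so far in an ADME assay on L6 cells (Rattus norvegicus) for cytotoxicity, read by fluorescence and resazurin assay, with a stated time of 72 h; a lower number here means that less compound is needed, a higher number that more compound is needed for the effect:
compound 1 `Cc1cc(-c2ccc3[nH]c(=O)nc(-c4ccccc4)c3c2)ccn1` — > 50000 nM (a limit of the assay)
compound 2 `O=c1nc(-c2ccccc2)c2cc(-c3cccnc3)ccc2[nH]1` — > 50000 nM (a limit of the assay)
compound 3 `Cc1ccc(-c2ccc3[nH]c(=O)nc(-c4ccccc4)c3c2)cn1` — > 50000 nM (a limit of the assay)

Compound 3 gives only a limit in this assay, and so do the two other measured compounds; all three sit at the limit of > 50000 nM in this assay, at which 3 of the 3 values shown sit. The steps from compound 1 to compound 2 (a step that the two limits leave unreadable from compound 1 to compound 2), from compound 1 to compound 3 (a step that the two limits leave unreadable from compound 1 to compound 3) and from compound 2 to compound 3 (a step that the two limits leave unreadable from compound 2 to compound 3) are therefore unreadable in size and show no effect within the range this assay can report.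

Compound 4 `Cc1ccncc1-c1ccc2[nH]c(=O)nc(-c3ccccc3)c2c1` is not yet measured. It differs from compound 3 only in the pyridyl substituent: 4-methylpyridin-3-yl in place of 6-methylpyridin-3-yl on an aromatic carbon. The measured steps all concern exchanges of this same substituent and none produced a readable number, so no step beyond the limit is expected from compound 3 to compound 4 (a step that the limit leaves unreadable from compound 3 to compound 4). For compound 4 the expected value in this assay is 80000 nM, in the range 40000 nM to 200000 nM, most probably reported again only as a limit.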

Compound 4, half-maximal effective concentration: > 50000 nM
Compound 4 gave a limit, no number; the forecaster's own chance of this, stated with the estimate: 85%; the middle value lies beyond the limit too.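

Compound 4, like compounds 1, 2 and 3, gives only a limit in this assay, so no step among these four compounds can be read: the limit of > 50000 nM in this assay, at which 4 of the 4 values shown sit. The compounds shown leave open at what concentration any of them would reach the effect in this assay, and whether exchanging the pyridyl substituent on the shared core changes that concentration.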